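The source may hold more compounds than are shown below. What is called first, only, known or untested is meant among the compounds shown, and "the series" means these compounds.

Going by the values given here, in a functional assay on HT-1080 cells (Homo sapiens) for cytotoxicity, read by MTT assay, with a stated time of 72 h (on this read-out lower numbers stand for stronger inhibition and higher numbers for weaker inhibition), compound 1 `COc1ccc(/C=C2\CCC/C(=C\c3ccccc3Cl)C2=O)cc1OC` gives 6800 nM and compound 2 `COc1cccc(/C=C2\CCC/C(=C\c3ccc(OC)c(OC)c3)C2=O)c1` gives 4600 nM, so the only two numbers available lie within the scatter of each other. Compound 3 `COc1ccc(/C=C2\CCC/C(=C\c3ccc(OC)c(OC)c3)C2=O)cc1` has yet to be measured in this assay. It differs from compound 2 by a single change, 4-methoxyphenyl in place of 3-methoxyphenyl on a double-bonded chain carbon bound to a double-bonded ring carbon. The two compounds have the same atoms, joined differently.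

Among the compounds with values here, one measured step bears on this change, since it falls at the same place: a 1.5-fold lower number from compound 1 to compound 2 (0.17 log units; within the scatter). That step exchanged 2-chlorophenyl for 3-methoxyphenyl, a different swap from the one at hand, and the data contain no direct comparison of 3-methoxyphenyl with 4-methoxyphenyl. Within the data shown here, with only this small step as a guide, no shift beyond the scatter is expected in either direction. The estimated step is a 1.1-fold higher number from compound 2 to compound 3 (0.04 log units; within the scatter), which is expected to stay within the scatter. Compound 3 is expected at 5000 nM, with an estimated range of 2000 nM to 12000 nM.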

Compound 3, half-maximal inhibitory concentration: 7200 nM
For compound 3 the middle estimate is 1.4-fold (0.16 log units) below the measured one; measured number inside the range.
By their numbers in this assay, from the lowest: compounds 2, 1 and 3 (each within the scatter of the next).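

In this assay, going by these compounds alone, the change to 4-methoxyphenyl in place of 3-methoxyphenyl on a double-bonded chain carbon bound to a double-bonded ring carbon gives the first direct comparison of these two groups, which have the same atoms joined differently, and the step (a 1.6-fold higher number from compound 2 to compound 3 (0.19 log units; within the scatter)) stays within the scatter. At the same place, 4-methoxyphenyl in place of 2-chlorophenyl (a 1.1-fold higher number from compound 1 to compound 3 (0.02 log units; within the scatter)) also stays within the scatter, so the three groups now seen there, 2-chlorophenyl, 3-methoxyphenyl and 4-methoxyphenyl, cannot be told apart on this read-out. No independent measurement is available to account for this result.

The three compounds leave open whether a different kind of group at this place, such as a phenyl ring carrying an amine or a carboxylic acid, or a longer chain in place of the methoxy group, would give a step beyond the scatter. They also leave open how 2-methoxyphenyl would compare with 2-chlorophenyl here, and whether the same lack of separation would hold on cells other than those used in this assay.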